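The source may hold more compounds than are shown below. What is called first, only, known or untested is meant among the compounds shown, and "the series" means these compounds.

Of the compounds shown here, two have been measured in an assay on liver for inhibition of sterol O-acyltransferase 1 (Rattus norvegicus), using microsomes; on this read-out lower numbers stand for stronger inhibition and higher numbers for weaker inhibition. Compound 1, `CCCCCCNS(=O)(=O)NC(=O)Oc1c(C(C)C)cccc1C(C)C`, gives 21000 nM. Compound 2, `CC(C)c1cccc(C(C)C)c1NS(=O)(=O)NC(=O)Oc1c(C(C)(C)C)cccc1C(C)(C)C`, gives 16800 nM. These two numbers lie within the usual scatter of each other, and the measurements made so far do not tell the two compounds apart. Going by the values given here, no pair of measured compounds differs in just one place, and no step between measured compounds has been recorded.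

Compound 3, `Cc1cc(C(C)(C)C)c(OC(=O)NS(=O)(=O)Nc2c(C(C)C)cccc2C(C)C)c(C(C)(C)C)c1`, has not yet been measured. It differs from compound 2 in one place: methyl in place of hydrogen on an aromatic carbon. Among the measured compounds no pair differs by this kind of change, and the size of such a step cannot be read from an earlier pair. The expectation is a step from compound 2 to compound 3 of no more than the scatter, in either direction. Compound 3 is expected to give 15000 nM in this assay, with a range from 6000 nM to 40000 nM. The step this estimate means, a 1.1-fold lower number from compound 2 to compound 3 (0.05 log units; within the scatter), is expected to remain within the scatter.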

Compound 3, half-maximal inhibitory concentration: 13500 nM
Estimate against measurement, compound 3: 1.1-fold (0.05 log units) above; low and high end bracket the measured number.
By their numbers in this assay, from the lowest: compounds 3, 2 and 1 (each within the scatter of the next).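

In this assay, going by these compounds alone, this is the first pair of compounds that differ in only one place, which gives a direct reading of a single change: a 1.2-fold lower number from compound 2 to compound 3 (0.09 log units; within the scatter). Methyl in place of hydrogen on this aromatic carbon, meta to two tert-butyl groups and para to a large group, therefore does not separate compound 3 from compound 2 on this read-out. The earlier values could not show this, since they came from compounds differing in more than one place, and no measurement shown here bears on why this step is so small.

From the compounds shown here alone, it remains open whether a different group at this same position, such as an amine, a carboxylic acid or a longer chain, would give a step beyond the scatter. Going by these compounds, it is also open whether methyl on this carbon would give a step of similar size in a compound carrying other groups in place of the two tert-butyl groups.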